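Swapping a sulfonamide for an acetamide on a biaryl scaffold

The source may hold more compounds than are shown below. What is called first, only, known or untested is meant among the compounds shown, and "the series" means these compounds.

Measured compounds and their values:
compound 1, `CCOC(=O)C1CCCC(c2ccc(OCC)cc2)N1`: 48%
compound 2, `CCOC(=O)c1cccc(-c2ccc(CN3CCCCC3)cc2)c1`: 68%
compound 3, `CCOc1ccc(-c2cccc(S(=O)(=O)N(C)C)c2)cc1`: 63%

In an assay on COS-7 cells for inhibition of patatin-like phospholipase domain-containing protein 2 (Mus musculus), tested at 200 uM (a higher number here means more inhibition at the concentration tested (going by the name of the read-out), a lower number less inhibition), compound 3 stands second of the three numbers; its value sits within the scatter of compound 2 and beyond the scatter above compound 1. Compound 4, `CCOc1ccc(-c2cccc(NC(C)=O)c2)cc1`, is not yet measured. It differs from compound 3 in one place: acetamido in place of dimethylsulfamoyl on an aromatic carbon. Going by the values given here, no measured pair shows this change, so its size is unknown from the numbers at hand. The step of a number 8 percentage points lower from compound 3 to compound 4 (within the scatter) is expected to be small, if anything a modest loss, and may well fall within the scatter. Compound 4 is therefore estimated at 55%, with a range from 35% to 75%.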

Compound 4, a percentage reported as inhibition, at one concentration (the size of the read-out at that concentration, not a potency): 52%
Estimate against measurement, compound 4: 3 percentage points above; the range from low to high includes it.
By their numbers in this assay, from the lowest: compounds 1 and 4 (each within the scatter of the next); then compounds 3 and 2 (each within the scatter of the next).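

In this assay, going by these compounds alone, the step with acetamido in place of dimethylsulfamoyl on an aromatic carbon is a number 11 percentage points lower from compound 3 to compound 4 (beyond the scatter), the first evidence that the group at this place affects the read-out. Compound 4 still gives 52%, so this single pair shows a modest loss rather than an abolished read-out. Nothing measured here explains the step.

The heavy-atom count and the hydrogen-bond donor count change together in this one step, so their contributions cannot be separated. Going by these compounds, how an amine or a carboxylic acid on this carbon would read remains open.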